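The source may report more compounds than this note shows. Statements on the series, on what has been measured and on what is new or still open speak of the compounds shown alone.

Compound 1 `CCO/N=C(\CCN1CCN(c2cccc(OC)c2)CC1)c1ccccc1`: 2680 nM
Compound 2 `CCO/N=C(\CCN1CCN(c2ccc(OC)cc2)CC1)c1ccccc1`: > 10000 nM

In a functional assay on HEK293 cells with D(4) dopamine receptor (Homo sapiens) as the target, read by FLIPR (on this read-out higher numbers stand for an effect only at larger amounts of compound and lower numbers for an effect already at smaller amounts), compound 1 gives 2680 nM. For compound 2 the read-out is only a limit of the assay, > 10000 nM, as described by the limit of > 10000 nM in this assay, at which 1 of the 2 values shown sits. The step of an at least 3.7-fold higher number from compound 1 to compound 2 (0.57 log units; beyond the scatter) is the only measured one, and it places compound 2 as the one of the two that acts only at larger amounts of compound.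

Compound 3 `CCO/N=C(\CCN1CCN(c2nccs2)CC1)c1ccccc1` differs from compound 2 in one place: 1,3-thiazol-2-yl in place of 4-methoxyphenyl on an amine nitrogen in a ring. Among the compounds with values here, no measured step exchanges the ring on that amine nitrogen for a different kind of ring; the single step from compound 1 to compound 2 only moves a methoxy group within the same ring, so it cannot be carried over directly. Starting from a limit, any real number for compound 3 would be read as a step toward smaller amounts of compound, and a limit again would show no step at all.

Compound 3 is expected to give 3000 nM in this assay. Its expected range runs from 500 nM to 20000 nM. The estimated step is an at least 3.3-fold lower number from compound 2 to compound 3 (0.52 log units; beyond the scatter).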

Compound 3, half-maximal effective concentration: 81.8 nM
Estimate against measurement, compound 3: 37-fold (1.56 log units) above; the measured number lies below the stated range.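

The group on this amine nitrogen of the six-membered ring can do far more than the earlier pair showed, since a lower number here means an effect at smaller amounts of compound: in this assay, 1,3-thiazol-2-yl in place of 4-methoxyphenyl gives an at least 120-fold lower number from compound 2 to compound 3 (2.08 log units; beyond the scatter), and in place of 3-methoxyphenyl it gives a 33-fold lower number from compound 1 to compound 3 (1.52 log units; beyond the scatter). The first of these steps gives only a minimum size, since compound 2 sits at a limit of the assay and has no exact number: the limit of > 10000 nM in this assay, at which 1 of the 3 values shown sits. The second step rests on two real numbers, so it is the firmer measure, and it shows that exchanging the whole ring here matters beyond moving a methoxy group around the same ring, the change behind an at least 3.7-fold higher number from compound 1 to compound 2 (0.57 log units; beyond the scatter).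

The exchange alters several things at once, namely ring size, the hetero atoms and the presence of a methoxy group, so these compounds cannot say which of them accounts for the step. As far as these compounds go, it also remains open how an unsubstituted phenyl, a pyridin-2-yl or a 1,3-oxazol-2-yl group would behave at this position.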